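A few compounds are considered here, and "the series" means these few. Any claim that something is new, unique, unknown or untested is made for them only; others in the source may bear on it.

In a functional assay on DU-145 cells (Homo sapiens) for inhibition, read by trypan blue exclusion, with a stated time of 72 h (a lower number here means a stronger inhibitor, a higher number a weaker inhibitor), compound 1 `Cn1c(=O)c(S(=O)(=O)c2ccc(F)cc2F)cc2cnc(Nc3ccc4occc4c3)nc21` gives 15000 nM as its half-maximal inhibitory concentration. Compound 2 `Cn1c(=O)c(S(=O)(=O)c2ccc(F)cc2F)cc2cnc(Nc3ccc4c(c3)CC(=O)N4)nc21` gives 100000 nM and so holds the higher of the two numbers, making it the weaker inhibitor of the pair. Compound 3 `Cn1ccc2cc(Nc3ncc4cc(S(=O)(=O)c5ccc(F)cc5F)c(=O)n(C)c4n3)ccc21` awaits measurement. Its difference from compound 2 a group of 10 heavy atoms (9 carbon, 1 nitrogen; one five-membered aromatic ring with 1 hetero atom, one six-membered aromatic ring of carbon only) in place of a group of 10 heavy atoms (8 carbon, 1 nitrogen, 1 oxygen; one five-membered non-aromatic ring with 1 hetero atom, one six-membered aromatic ring of carbon only), on a nitrogen on an aromatic ring brings in 1-methyl-1H-indol-5-yl on a nitrogen on an aromatic ring and, as in compound 1, restores a five-membered aromatic ring with 1 hetero atom. Within the data shown here, the one measured step bearing on this is a 6.7-fold higher number from compound 1 to compound 2 (0.82 log units; beyond the scatter) in which a five-membered aromatic ring gave way to a non-aromatic one. Compound 3 turns that ring change back, although its group holds nitrogen where the group of compound 1 holds oxygen, so a step of similar size towards a lower number is expected in this assay on this single piece of evidence. The estimate therefore means a 5.0-fold lower number from compound 2 to compound 3 (0.70 log units; beyond the scatter) as the expected change. Compound 3 is estimated at 20000 nM with 6000 nM to 60000 nM as the expected range.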

Compound 3, half-maximal inhibitory concentration: 750 nM
Compound 3: the middle estimate sits 27-fold (1.43 log units) above what was measured; measured number outside the range, below it.
By their numbers in this assay, from the lowest: compound 3; then compound 1; then compound 2.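

In this assay, the group on a nitrogen on an aromatic ring turns out to matter far more than the first step suggested: a 130-fold lower number from compound 2 to compound 3 (2.12 log units; beyond the scatter) is a much larger change than a 6.7-fold higher number from compound 1 to compound 2 (0.82 log units; beyond the scatter), and it makes compound 3 the strongest inhibitor of the three. Regaining a five-membered aromatic ring therefore cannot be the whole story, since compound 1 and compound 3 both carry such a ring with one hetero atom, and yet 1-methyl-1H-indol-5-yl in place of 1-benzofuran-5-yl gives a 20-fold lower number from compound 1 to compound 3 (1.30 log units; beyond the scatter). Nothing available explains this difference between two groups of such similar shape on paper.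

As far as these compounds go, what remains open is whether the gain belongs to the ring nitrogen or to the methyl group on it, as compound 3 changes both relative to compound 1, and a 1H-indol-5-yl group carrying hydrogen on that nitrogen, or an indole with an ethyl group there, would separate the two. From the compounds shown here alone, it is also open whether the ranking of these three compounds extends beyond this single cell assay to any other read-out.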